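The source may hold more compounds than are shown below. What is called first, only, known or untested is meant among the compounds shown, and "the series" means these compounds.

Compound 1 `CCCNc1nn2c(=O)cc(C(F)(F)F)nc2s1` gives 310 nM in an ADME assay on cells for inhibition of Intestinal-type alkaline phosphatase (Homo sapiens), read by luminescence, with stated times of 7 min and 20 min; a lower number here means a stronger inhibitor, a higher number a weaker inhibitor.
Compound 2 `Cc1ccc(-c2nn3c(=O)cc(C(F)(F)F)nc3s2)cc1C` gives 1750 nM in this assay.

For the measured compounds named here, of the two numbers measured so far, compound 1 holds the lower one, and compound 2 sits clearly beyond the scatter from it. The unmeasured compound 3 `O=c1cc(C(F)(F)F)nc2sc(-c3ccccc3F)nn12` differs from compound 1 in one place: 2-fluorophenyl in place of propylamino on an aromatic carbon. Going by the values given here, no step between measured compounds is known that matches this change, but compound 2 also carries a ring on the shared core in place of a chain, and compound 2 gives 1750 nM, while compound 1 gives 310 nM. On that basis a weakening step beyond the scatter is expected for the move to compound 3, though the size is uncertain. The estimate for compound 3 is 1500 nM, expected to fall between 500 nM and 4500 nM, which corresponds to an expected step of a 4.8-fold higher number from compound 1 to compound 3 (0.68 log units; beyond the scatter).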

Compound 3, half-maximal inhibitory concentration: > 100000 nM
Compound 3: no number, only a limit; the forecaster's own chance of this, stated with the estimate: 5%; at least 66-fold (1.82 log units) between middle value and limit.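

Putting 2-fluorophenyl in place of propylamino on this aromatic carbon gives an at least 320-fold higher number from compound 1 to compound 3 (2.50 log units; beyond the scatter) in this assay, so inhibition can depend very strongly on what sits at this position. The result for compound 3 is a limit of the assay, not a number: the limit of > 100000 nM in this assay, at which 1 of the 3 values shown sits. Compound 2 also carries a ring at this place and gives 1750 nM, so among these compounds a ring there is not enough on its own to remove measurable inhibition.

The compounds shown cannot separate the loss of the nitrogen-linked propylamino chain from the effect of the fluorine on the new ring. Unsubstituted phenyl, a plain propyl chain or a longer butylamino chain on this carbon would be needed to tell these apart.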